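Nitro on the Terminal Phenyl of the Urea

The source may report more compounds than this note shows. Statements on the series, on what has been measured and on what is new or still open speak of the compounds shown alone.

Compound 1 `Cc1ccccc1NC(=O)Nc1cccc(CNc2ncnc3ccccc23)c1` and compound 2 `COc1cc2ncnc(NCc3cccc(NC(=O)Nc4ccccc4)c3)c2cc1OC` carry the same benzylamine-linked urea on different versions of the shared core. In a functional assay on HepG2 cells (Homo sapiens) for antiproliferative activity, read by MTT assay (on this read-out higher numbers stand for weaker inhibition and lower numbers for stronger inhibition), compound 1 reaches only the limit of the assay, > 50000 nM. That limit of compound 1 is one of the two values shown (the limit of > 50000 nM in this assay, at which 1 of the 2 values shown sits). In this assay, going by the values given here, compound 2 gives 19700 nM, the only number among the two values shown. Compound 3 `COc1cc2ncnc(NCc3cccc(NC(=O)Nc4ccc([N+](=O)[O-])cc4)c3)c2cc1OC` differs from compound 2 by nitro in place of hydrogen on an aromatic carbon, placed para to a large group. Among the compounds with values here, with no measured step as guide, the change is expected to be small, a 1.4-fold lower number from compound 2 to compound 3 (0.15 log units; within the scatter), within or near the scatter. Compound 3 is estimated at 14000 nM, between 4000 nM and 45000 nM.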

Compound 3, half-maximal inhibitory concentration: 18800 nM
Estimate against measurement, compound 3: 1.3-fold (0.13 log units) below; the range from low to high includes it.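

Nitro in place of hydrogen on an aromatic carbon, para to a large group, gives a 1.0-fold lower number from compound 2 to compound 3 (0.02 log units; within the scatter) in this assay. Going by these compounds alone, this is the first step read at this position, and it shows that the terminal phenyl carries nitro with no change beyond the scatter in this assay. Compound 1 remains a limit of the assay and not a number: the limit of > 50000 nM in this assay, at which 1 of the 3 values shown sits.

On these data alone, whether an amine or a carboxylic acid at this position would move the number stays open. So does whether nitro elsewhere on the terminal phenyl would behave in the same way.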